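Methyl-to-fluoro swap at two different aryl sites

The source may hold more compounds than are shown below. What is called first, only, known or untested is meant among the compounds shown, and "the series" means these compounds.

Compound 1 `Cc1cccc(COc2ccc(-c3cc(CN4CCN(Cc5ccc(C(F)(F)F)cc5)CC4)no3)cc2)c1` and compound 2 `Fc1cccc(COc2ccc(-c3cc(CN4CCN(Cc5ccc(C(F)(F)F)cc5)CC4)no3)cc2)c1` share one core and differ in a single place: fluoro in place of methyl on an aromatic carbon. In a functional assay on Mahlavu cells (Homo sapiens) for antiproliferative activity, read by sulforhodamine B assay, with a stated time of 72 h (on this read-out higher numbers stand for weaker inhibition and lower numbers for stronger inhibition), compound 1 gives 2500 nM and compound 2 gives 2900 nM. The step between them is a 1.2-fold higher number from compound 1 to compound 2 (0.06 log units; within the scatter), so the two values are indistinguishable on this read-out. Compound 3 `Cc1cc(OCc2cccc(C#N)c2)ccc1-c1cc(CN2CCN(Cc3ccc(C(F)(F)F)cc3)CC2)no1` is built on a different core; the difference between the core of compound 3 and that of compound 1 is not broken down here. In this assay compound 3 gives 500 nM, the lowest of the three numbers, with its gaps to compound 1 and to compound 2 both beyond the scatter.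

Compound 4 `N#Cc1cccc(COc2ccc(-c3cc(CN4CCN(Cc5ccc(C(F)(F)F)cc5)CC4)no3)c(F)c2)c1` has not been measured. It differs from compound 3 by fluoro in place of methyl on an aromatic carbon. This is the same kind of change as that between compound 1 and compound 2, but not the same: in the measured pair the site is meta to a large group, whereas in compound 4 it is ortho to a large group and meta to a (3-cyanobenzyl)oxy group. For the measured compounds named here, only one measured instance of this kind of change exists, and it read a 1.2-fold higher number from compound 1 to compound 2 (0.06 log units; within the scatter), within the scatter. In this assay the expected step is accordingly small, a 1.2-fold higher number from compound 3 to compound 4 (0.08 log units; within the scatter), resting on that single step a 1.2-fold higher number from compound 1 to compound 2 (0.06 log units; within the scatter). Compound 4 is estimated at about 600 nM in this assay. Compound 4 is expected to fall in a deliberately wide range, estimated from 250 nM to 1500 nM. The range is kept wide because the site of the change is not the same as in the measured pair, and no second instance is available to check it.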

Compound 4, half-maximal inhibitory concentration: 400 nM
For compound 4 the middle estimate is 1.5-fold (0.18 log units) above the measured one; measured number inside the range.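

In this assay the new step reads a 1.3-fold lower number from compound 3 to compound 4 (0.10 log units; within the scatter), so fluoro in place of methyl on an aromatic carbon leaves compound 4 indistinguishable from compound 3 on this read-out. Set beside the earlier pair, the change reads the same on the two cores, and no dependence on the core can be seen: the same change on two cores in this assay, a 1.2-fold higher number (0.06 log units; within the scatter) from compound 1 to compound 2 and a 1.3-fold lower number (0.10 log units; within the scatter) from compound 3 to compound 4, 1.5-fold (0.16 log units) apart, within the scatter of two such steps. For the compounds shown here, this rests on only two pairs, with the site in compound 4 ortho to a large group and meta to a (3-cyanobenzyl)oxy group, so it does not show that the swap would stay within the scatter on further cores or at other sites of the aromatic ring, and it gives no reason why neither step goes beyond the scatter.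

The compounds shown leave open whether a different replacement on the same aromatic carbon, such as chloro, methoxy or an amine, would give a step beyond the scatter where methyl and fluoro do not. Also open, going by these compounds, is whether the same swap stays within the scatter when the nitrile is exchanged for a carboxylic acid or the trifluoromethyl group for a longer chain.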